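A few compounds are considered here, and "the series" means these few. Any claim that something is new, unique, unknown or untested is made for them only; others in the source may bear on it.

Compound 1 `O=C(Nc1cccc(-n2cc(-c3ccncc3)c(-c3cc(O)cc(Cl)c3)n2)c1)Nc1ccc(Cl)c(C(F)(F)F)c1` is read in a functional assay on CCRF-CEM cells (Homo sapiens) for inhibition, read by sulforhodamine B assay, with a stated time of 48 h, tested at 1 uM (on this read-out lower numbers stand for a stronger effect and higher numbers for a weaker effect at the one concentration tested), where it gives 92%. Among the two compounds measured there it stands highest, and the nearest of them is compound 2 `O=C(Nc1cccc(-n2cc(-c3ccncc3)c(-c3cc(O)cc(Cl)c3)n2)c1)Nc1ccc(Cl)c(Cl)c1`, which in this assay gives 76%. For the measured compounds named here, the one measured step between these two, a chloro in place of trifluoromethyl on an aromatic carbon, reads a number 16 percentage points lower from compound 1 to compound 2 (beyond the scatter), a modest move beyond the scatter.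

The unmeasured compound 3 `COc1cc(Cl)cc(-c2nn(-c3cccc(NC(=O)Nc4ccc(Cl)c(C(F)(F)F)c4)c3)cc2-c2ccncc2)c1` differs from compound 1 in a single place: methyl in place of hydrogen on an oxygen on an aromatic ring. This change, hydroxy to methoxy on the 3-chloro-5-hydroxyphenyl ring, is not touched by the measured step, which concerns a different ring altogether. Going by the values given here, no step in the data therefore bears on it, and there is nothing from which a direction can be taken. Since compound 1 already sits at the upper end of the scale in this assay, the room for a move upward is small, and any move downward cannot be anchored in a measured pair.

Compound 1 to compound 3 is therefore expected to give a step of about a number 2 percentage points lower from compound 1 to compound 3 (within the scatter), essentially no change beyond the scatter. Compound 3 is estimated at 90% in this assay, with a range from 68% to 104%.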

Compound 3, a percentage reported as activity, at one concentration (the size of the read-out at that concentration, not a potency): 37%
Compound 3: the middle estimate sits 53 percentage points above what was measured; the measured number lies below the stated range.
By their numbers in this assay, from the lowest: compound 3; then compound 2; then compound 1.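

The oxygen on the 3-chloro-5-hydroxyphenyl ring turns out to be a sensitive place in the series: in this assay, capping the hydroxy as methoxy gives a number 55 percentage points lower from compound 1 to compound 3 (beyond the scatter), a stronger effect at the one concentration tested. For the compounds shown here, this single added methyl, one heavy atom with no ring and no charge, moves the read-out further than the only earlier change, on the other aromatic ring, which gave a number 16 percentage points lower from compound 1 to compound 2 (beyond the scatter). The earlier pair showed only that the read-out responds to the substituent on that other ring, and nothing in the data accounts for the size of the step at the oxygen.

The compounds shown leave open whether the step belongs to methyl in particular or would also appear with a longer chain such as ethyl on the same oxygen, or with an amine in place of the hydroxy. They also leave open whether methoxy and the chloro in place of trifluoromethyl would add up when combined in a single compound, since each change is seen here only on its own, starting from compound 1.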